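Methyl in place of methoxy on an aromatic carbon

A few compounds are considered here, and "the series" means these few. Any claim that something is new, unique, unknown or untested is made for them only; others in the source may bear on it.

Of the compounds shown here, two have numbers so far in an ADME assay on CRFK cells (Felis catus) for cytotoxicity; on this read-out higher numbers stand for lower toxicity in this test and lower numbers for higher toxicity in this test. Compound 1 `CCN(CC)CN1C(=O)/C(=N/NC(=S)Nc2ccc(C)cc2)c2ccccc21` gives 3800 nM, and compound 2 `CCN(CC)CN1C(=O)/C(=N/NC(=S)Nc2ccc(OC)cc2)c2cc(Cl)ccc21` gives 3600 nM. Compound 2 therefore stands within the scatter of compound 1, and the two cannot be separated on this read-out.

Compound 3 `CCN(CC)CN1C(=O)/C(=N/NC(=S)Nc2ccc(C)cc2)c2cc(Cl)ccc21` has not yet been measured. It departs from compound 2 by methyl in place of methoxy on an aromatic carbon, para to a large group. Among the compounds with values here, the two measured compounds differ in more than one place, so no measured step bears directly on this change.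

With so little data, the value of compound 2 at 3600 nM serves as the anchor, and no shift in either direction can be argued from the numbers in hand. The expected change is small, with a 1.0-fold higher number from compound 2 to compound 3 (0.01 log units; within the scatter) estimated to stay within the scatter. The estimate for compound 3 is 3700 nM, with an expected range from 1800 nM to 7500 nM.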

Compound 3, half-maximal cytotoxic concentration: 17500 nM
Compound 3: middle estimate off by 4.7-fold (0.67 log units), on the low side; measured number outside the range, above it.
By their numbers in this assay, from the lowest: compounds 2 and 1 (each within the scatter of the next); then compound 3.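

In this assay, methyl in place of methoxy on an aromatic carbon, para to a large group, gives a 4.9-fold higher number from compound 2 to compound 3 (0.69 log units; beyond the scatter) with the chloro group kept in place, so this position does respond to the change. Compound 1 and compound 2 could not show this, since they differ in more than one place and their values lie within the scatter of each other. Chloro in place of hydrogen on an aromatic carbon, with the 4-methylphenyl group kept, gives a 4.6-fold higher number from compound 1 to compound 3 (0.66 log units; beyond the scatter) and so shows that the closeness of compound 1 and compound 2 does not mean that either place is silent, though no measurement at hand bears on the reason for either step.

From the compounds shown here alone, whether the step between methoxy and methyl keeps its size with hydrogen in place of the chloro group on the shared core remains open. Going by these compounds, it is also open whether the higher number in this test is particular to methyl, or whether hydrogen, ethyl, fluoro or a dimethylamino group at the same position would read in the same way.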